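A few compounds are considered here, and "the series" means these few. Any claim that something is new, unique, unknown or untested is made for them only; others in the source may bear on it.

In an ADME assay on L02 cells (Homo sapiens) for cytotoxicity, read by MTT assay, with a stated time of 72 h (on this read-out lower numbers stand for stronger inhibition and higher numbers for weaker inhibition), compound 1 `C=CC(=O)Nc1cccc(Oc2nc(Nc3cccc(OC)c3)nc3c2CSCC3)c1` gives 48900 nM. Compound 2 `C/C=C/C(=O)Nc1cccc(Oc2nc(Nc3cccc(OC)c3)nc3c2CSCC3)c1` reports only a limit, > 50000 nM. Compound 3 `COc1cccc(Nc2nc3c(c(Oc4cccc(NC(=O)C=C(C)C)c4)n2)CSCC3)c1` also reports only a limit, > 50000 nM, so it has no number of its own and stands at the limit of > 50000 nM in this assay, at which 2 of the 3 values shown sit.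

Compound 4 `COc1ccc(Nc2nc3c(c(Oc4cccc(NC(=O)C=C(C)C)c4)n2)CSCC3)cn1` differs from compound 3 in one place: 6-methoxypyridin-3-yl in place of 3-methoxyphenyl on a nitrogen on an aromatic ring. In words, this is 6-methoxypyridin-3-yl in place of 3-methoxyphenyl on a nitrogen on an aromatic ring.

The measured steps all lie on a carbonyl carbon, and none changes this group, so they bear on the change only indirectly. They are an at least 1.0-fold higher number from compound 1 to compound 2 (0.00 log units; that floor lies within the scatter), an at least 1.0-fold higher number from compound 1 to compound 3 (0.00 log units; that floor lies within the scatter) and a step that the two limits leave unreadable from compound 2 to compound 3. Among the compounds with values here, no step of this kind has been measured. The expectation therefore rests on compound 3 and on an at least 1.0-fold higher number from compound 1 to compound 3 (0.00 log units; that floor lies within the scatter), and no shift beyond the scatter is expected in either direction in this assay.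

The estimated step is a number no higher from compound 3 to compound 4 (the limit leaves the size open). For compound 4 the expected value is 50000 nM, with an estimated range of 28000 nM to 90000 nM.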

Compound 4, half-maximal inhibitory concentration: > 50000 nM
Compound 4: no number, only a limit; the forecaster's own chance of this, stated with the estimate: 70%; the middle value sits exactly at the limit.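

In this assay, within the data shown here, compound 3 and compound 4 are each recorded only as a limit, so no step between them can be read. The compounds shown leave open whether 6-methoxypyridin-3-yl in place of 3-methoxyphenyl on a nitrogen on an aromatic ring shifts this read-out at all.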